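A Bromo for a Methyl on the Shared Core

The source may report more compounds than this note shows. Statements on the series, on what has been measured and on what is new or still open speak of the compounds shown alone.

Of the compounds shown here, three have been measured in a functional assay on HBL-100 cells (Homo sapiens) for inhibition, read by sulforhodamine B assay, with a stated time of 48 h; on this read-out lower numbers stand for stronger inhibition of growth and higher numbers for weaker inhibition of growth. Compound 1 `COC(=O)[C@@]1(C)CCC=C2[C@@H]1CC[C@@H](C)[C@]2(C)Cc1c(C)[nH]c2c(Cl)cccc12` gives 22000 nM. Compound 2 `COC(=O)[C@@]1(C)CC[C@@H]2C3=C1CC[C@@H](C)[C@]3(C)C[C@@H]1c3ccccc3N[C@H]21`, built on a different core, gives 78000 nM. Compound 3 `COC(=O)[C@@]1(C)CC[C@@H]2C3=C1CC[C@@H](C)[C@]3(C)C[C@@H]1c3cc(C)ccc3N[C@H]21` gives 15000 nM; it carries a methyl on an aromatic carbon where compound 2 carries hydrogen. Going by the values given here, the only step between compounds that differ in a single place is a 5.2-fold lower number from compound 2 to compound 3 (0.72 log units; beyond the scatter). Compound 3 thus shows the lowest number of the three; its gap to compound 1 is within the scatter, while its gap to compound 2 lies beyond it.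

Compound 4 `COC(=O)[C@@]1(C)CC[C@@H]2C3=C1CC[C@@H](C)[C@]3(C)C[C@@H]1c3cc(Br)ccc3N[C@H]21` differs from compound 3 by bromo in place of methyl on an aromatic carbon. Among the compounds with values here, no measured step exchanges a methyl for a bromo, so the only step that bears on this position is the one from compound 2 to compound 3, which shows that a small group at this carbon can move the number beyond the scatter. Whether a bromo behaves here like the methyl of compound 3 or like the hydrogen of compound 2 cannot be read from these data, so the expected step of a 1.2-fold lower number from compound 3 to compound 4 (0.06 log units; within the scatter) is one of no change beyond the scatter. Compound 4 is therefore estimated at 13000 nM, with a range from 5000 nM to 35000 nM.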

Compound 4, concentration for 50% growth inhibition: 34000 nM
Compound 4: the middle estimate sits 2.6-fold (0.42 log units) below what was measured, within the range that was stated.
By their numbers in this assay, from the lowest: compounds 3, 1 and 4 (each within the scatter of the next, the first and the last beyond it); then compound 2.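

On this aromatic carbon the choice of group matters in graded fashion: in this assay, bromo in place of methyl gives a 2.3-fold higher number from compound 3 to compound 4 (0.36 log units; beyond the scatter), while bromo in place of hydrogen gives a 2.3-fold lower number from compound 2 to compound 4 (0.36 log units; beyond the scatter). Both steps lie beyond the scatter, so bromo follows neither the methyl nor the hydrogen, and the three compounds on the shared core run from the lowest number with methyl, through bromo, to the highest with hydrogen; any substituent shown here improves on hydrogen, but the two substituents are not interchangeable. Methyl and bromo match in their counts of heavy atoms and hydrogen-bond donors and acceptors, so those counts do not separate them, and no supporting measurement is available to account for the gap between them.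

As far as these compounds go, three groups at one carbon fix an order but no rule, and it remains open where a methoxy, an ethyl, an amine or a carboxylic acid at this carbon would fall. From the compounds shown here alone, it is equally open whether the same order would hold at the other aromatic carbons of this ring or on the core of compound 1.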